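The source may hold more compounds than are shown below. What is called first, only, known or untested is meant among the compounds shown, and "the series" means these compounds.

Of the compounds shown here, two have numbers so far in an ADME assay on THP-1 cells (Homo sapiens) for cytotoxicity, with a stated time of 48 h; a lower number here means a stronger inhibitor, a higher number a weaker inhibitor. Compound 1 `[O-][n+]1onc2cc(/C=C\[S+]([O-])c3ccccc3)ccc21` gives 105000 nM, while compound 2 `O=S(=O)(CCO)Cc1ccc2c(c1)no[n+]2[O-]` gives 300000 nM, the higher of the two, with a gap between them that lies beyond the scatter. Compound 3 `C=CS(=O)(=O)Cc1ccc2c(c1)no[n+]2[O-]` has not yet been measured. It keeps the core of compound 2 and changes one group: vinyl in place of 2-hydroxyethyl on a sulfonyl sulfur. Among the measured compounds shown here, no measured pair shows this change, so the expectation is loose. Compound 1, which also has a double bond outside aromatic rings, gives 105000 nM, and this points to a lower number in this assay, by a step beyond the scatter, although a single compound is thin support. The estimated step is a 6.0-fold lower number from compound 2 to compound 3 (0.78 log units; beyond the scatter). Compound 3 is expected at 50000 nM, within an estimated range of 12000 nM to 200000 nM.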

Compound 3, half-maximal inhibitory concentration: 274000 nM
Beside the measured number, compound 3's estimate is 5.5-fold (0.74 log units) below it; measured number above the stated range.
By their numbers in this assay, from the lowest: compound 1; then compounds 3 and 2 (each within the scatter of the next).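

In this assay, among the compounds shown here, vinyl in place of 2-hydroxyethyl on a sulfonyl sulfur gives a 1.1-fold lower number from compound 2 to compound 3 (0.04 log units; within the scatter), a first direct reading of this position. At this place, removing the hydrogen-bond donor and acceptor of the 2-hydroxyethyl group and adding a double bond outside aromatic rings goes with no difference that can be told from scatter. No measurement at hand says why.

Going by these compounds, it remains open whether an amine, a carboxylic acid or a longer chain on this sulfonyl sulfur would give a number beyond the scatter of these two. Compound 1 differs from both in more than one place, so what sets its number of 105000 nM apart cannot be traced to any single group.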